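From compound 3 to compound 4: trifluoromethoxy for methoxycarbonyl

A few compounds are considered here, and "the series" means these few. Any claim that something is new, unique, unknown or untested is made for them only; others in the source may bear on it.

In an ADME assay for permeability, using PAMPA, at pH 7.4 (on this read-out higher numbers stand for higher permeability and lower numbers for lower permeability), compound 1 `CCc1ccc(NC(=O)Nc2cc(C)nc3ccccc23)cc1` gives 535 10^-6 cm/s, compound 2 `CC(=O)c1ccc(NC(=O)Nc2cc(C)nc3ccccc23)cc1` gives 473 10^-6 cm/s and compound 3 `COC(=O)c1ccc(NC(=O)Nc2cc(C)nc3ccccc23)cc1` gives 448 10^-6 cm/s. All three values lie within the scatter of one another, so compound 3 stands level with the other two.

Compound 4 `Cc1cc(NC(=O)Nc2ccc(OC(F)(F)F)cc2)c2ccccc2n1` carries trifluoromethoxy in place of methoxycarbonyl on an aromatic carbon, para to a large group: trifluoromethoxy in place of methoxycarbonyl on an aromatic carbon.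

The bearing evidence is the set of exchanges on that aromatic carbon. The changes a 1.2-fold lower number from compound 1 to compound 3 (0.08 log units; within the scatter) and a 1.1-fold lower number from compound 1 to compound 2 (0.05 log units; within the scatter) both stayed within the scatter, as did the smaller edit a 1.1-fold lower number from compound 2 to compound 3 (0.02 log units; within the scatter). Going by the values given here, no measured compound carries trifluoromethoxy, so the flat picture from these three compounds is carried over without direct support.

In this assay the expected step is a 1.1-fold higher number from compound 3 to compound 4 (0.03 log units; within the scatter), with nothing expected beyond the scatter. Compound 4 is estimated at 480 10^-6 cm/s, with an expected range of 240 10^-6 cm/s to 850 10^-6 cm/s.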

Compound 4, apparent permeability: 531 10^-6 cm/s
Beside the measured number, compound 4's estimate is 1.1-fold (0.04 log units) below it, within the range that was stated.
By their numbers in this assay, from the lowest: compounds 3, 2, 4 and 1 (each within the scatter of the next).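

In this assay the exchanges on this aromatic carbon now reach a group with fluorine and without a carbonyl: a 1.2-fold higher number from compound 3 to compound 4 (0.07 log units; within the scatter) and a 1.1-fold higher number from compound 2 to compound 4 (0.05 log units; within the scatter) and also a 1.0-fold lower number from compound 1 to compound 4 (0.00 log units; within the scatter) are further changes of the same flat kind. Going by these compounds alone, the flat picture at this position therefore holds across all four groups, with no order among the compounds to be read. No measurement on hand offers a reason for this flatness.

Still open, as far as these compounds go, is whether an amine or a carboxylic acid on this aromatic carbon would stay within the scatter in this assay as well. Also open, from the compounds shown here alone, is whether a longer chain in place of ethyl, or any change elsewhere on the shared core, would move the number beyond it.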